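Series notes: one more methyl on the long chain

A few compounds are considered here, and "the series" means these few. Any claim that something is new, unique, unknown or untested is made for them only; others in the source may bear on it.

Measured in a functional assay on SW480 cells (Homo sapiens) for antiproliferative activity, read by MTT assay, with a stated time of 48 h; a lower number here means a stronger inhibitor, a higher number a weaker inhibitor:
- compound 1 `CCC(CCO)n1cnc2c(Cl)ncnc21`: > 50000 nM (a limit)
- compound 2 `CCCCCCCCC(CCO)n1cnc2c(Cl)ncnc21`: 1370 nM
- compound 3 `CCCCCCCCCC(CCO)n1cnc2c(Cl)ncnc21`: 1150 nM
- compound 4 `CCCCCCCCCCC(CCO)n1cnc2c(Cl)ncnc21`: not yet measured

Compound 3 gives 1150 nM, within the scatter of compound 2 at 1370 nM. Compound 1 gives > 50000 nM, which is a limit of the assay. Both chain-bearing compounds therefore carry numbers well clear of that limit in this assay.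

Next is compound 4, which differs from compound 3 as follows: methyl in place of hydrogen on a saturated chain carbon, ten or more bonds along the chain from an aromatic nitrogen. This is methyl in place of hydrogen on a saturated chain carbon, ten or more bonds along the chain from an aromatic nitrogen.

Two large steps come from adding a whole chain: an at least 36-fold lower number from compound 1 to compound 2 (1.56 log units; beyond the scatter) with hexyl, and an at least 43-fold lower number from compound 1 to compound 3 (1.63 log units; beyond the scatter) with heptyl. They bear only loosely on a single added methyl. Among the measured compounds shown here, the closest precedent is the same replacement of hydrogen by methyl on the long chain, a 1.2-fold lower number from compound 2 to compound 3 (0.08 log units; within the scatter), which lies within the scatter. No step beyond the scatter is therefore expected, and direction cannot be called. The expected change is a 1.0-fold lower number from compound 3 to compound 4 (0.02 log units; within the scatter). For compound 4 the expected value is 1100 nM, with an estimated range of 550 nM to 2400 nM.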

Compound 4, half-maximal inhibitory concentration: 3160 nM
Estimate against measurement, compound 4: 2.9-fold (0.46 log units) below; the whole stated range lies below it.
By their numbers in this assay, from the lowest: compounds 3 and 2 (each within the scatter of the next); then compound 4. At a limit, above all of these: compound 1.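

In this assay, among the compounds shown here, this place on the long chain gives the first single methyl change beyond the scatter: the change reads as a 2.7-fold higher number from compound 3 to compound 4 (0.44 log units; beyond the scatter) and is modest, whereas the same replacement one bond nearer reads as a 1.2-fold lower number from compound 2 to compound 3 (0.08 log units; within the scatter) and stays within the scatter. The comparison with the shorter chain points the same way, with a 2.3-fold higher number from compound 2 to compound 4 (0.36 log units; beyond the scatter) as the ethyl step, so compound 4 stands above both compounds 2 and 3 and the chain series no longer holds level at its long end, while the large gain over the short chain persists, read as an at least 15-fold lower number from compound 1 to compound 4 (1.19 log units; beyond the scatter) against a reference compound. Compound 1 stands at a limit, so that last step is a bound and not a measured size: (the limit of > 50000 nM in this assay, at which 1 of the 4 values shown sits)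

Whether a longer chain would keep raising the number, or whether this rise is a single scattered-looking turn, stays open, and the compounds shown give no cause for it. Also open, going by these compounds, is how an amine or a carboxylic acid on the long chain would read in this assay at these chain lengths.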